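This account rests on a few compounds, and the source may have more. Where it says the series, first, only, none or still open, it means among the compounds named here.

Measured in a functional assay on DLD-1 cells (Homo sapiens), read by microscopy and crystal violet staining, with a stated time of 20 h, tested at 10 ug/mL; a lower number here means less inhibition, a higher number more inhibition at the concentration tested (going by the name of the read-out):

- compound 1 `O=C1NC(=S)S/C1=C\C=C\c1ccccc1OCc1ccncc1`: 62%
- compound 2 `O=C1NC(=S)S/C1=C\c1cc(Br)ccc1OCc1ccccc1Br`: 95%

Compound 1 stands lowest of the two numbers; the nearest, compound 2, gives a number higher by a margin beyond the usual scatter. Among the compounds with values here, no pair of measured compounds differs in only one place, so no single step between them can be read off.

Compound 3 `O=C1NC(=S)S/C1=C\C=C\c1ccccc1O` is not yet measured. It differs from compound 1 in one place: hydrogen in place of (pyridin-4-yl)methyl on an oxygen on an aromatic ring, that is, the (pyridin-4-yl)methoxy group of compound 1 becomes a hydroxy group.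

Within the data shown here, with no measured step to lean on, the expectation is a modest loss of inhibition in this assay , possibly no larger than the scatter. The step of a number 12 percentage points lower from compound 1 to compound 3 (beyond the scatter) is estimated as a small drop. For compound 3 the expected read-out in this assay is 50%, within a range from 25% to 80%.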

Compound 3, a percentage reported as inhibition, at one concentration (the size of the read-out at that concentration, not a potency): 65%
For compound 3 the middle estimate is 15 percentage points below the measured one; the measured number falls inside the stated range.
By their numbers in this assay, from the lowest: compounds 1 and 3 (each within the scatter of the next); then compound 2.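

In this assay, within the data shown here, the first comparison that differs in one place reads a number 3 percentage points higher from compound 1 to compound 3 (within the scatter). On this oxygen on an aromatic ring, the (pyridin-4-yl)methoxy group and the hydroxy group therefore cannot be told apart at the concentration tested, and the (pyridin-4-yl)methyl is not required for the inhibition seen with compound 3. No measured evidence is available to explain this flat step.

Among these compounds, compound 2 differs from the other compounds in more than one place, so no steps to it can be read. From the compounds shown here alone, whether a different group on the same oxygen, such as a methyl, a longer alkyl chain or a chain ending in an amine or a carboxylic acid, would separate from compound 3 remains open.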